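Swapping methyl for fluoro on a weak binder

The source may report more compounds than this note shows. Statements on the series, on what has been measured and on what is new or still open speak of the compounds shown alone.

Of the compounds shown here, two have been measured so far in an assay on isolated protein for inhibition of vitamin D3 receptor (Homo sapiens), read by fluorescence polarization; a lower number here means a stronger inhibitor, a higher number a weaker inhibitor. Compound 1 `Cc1ccc(N2CCN(C(=O)C3CCN(C(=O)c4ccc(S(C)(=O)=O)c([N+](=O)[O-])c4)CC3)CC2)cc1` is one of them. In this assay compound 1 gives > 60000 nM, which is a limit of the assay and not a number. Compound 2 `CN(Cc1cccc(F)c1)C(=O)CNC(=O)c1ccc(S(C)(=O)=O)c([N+](=O)[O-])c1` is the other. In this assay compound 2 gives > 60000 nM, again a limit rather than a number. Both values sit at the limit of > 60000 nM in this assay, at which 2 of the 2 values shown sit, so neither compound stands out from the other. Compound 3 `CS(=O)(=O)c1ccc(C(=O)N2CCC(C(=O)N3CCN(c4ccc(F)cc4)CC3)CC2)cc1[N+](=O)[O-]` has not yet been measured. It differs from compound 1 in one place: fluoro in place of methyl on an aromatic carbon. Among the compounds with values here, no measured pair shows such a change, and with compound 1 itself at a limit there is no number from which a direction could be read. The expected step of a number no higher from compound 1 to compound 3 (the limit leaves the size open) is therefore none beyond the scatter. Compound 3 is expected to give 60000 nM, with a likely range from 20000 nM to 200000 nM, most probably reported as a limit once more.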

Compound 3, half-maximal inhibitory concentration: > 60000 nM
Compound 3: only a limit was reported; the forecaster's own chance of this, stated with the estimate: 85%; the middle value lies on the limit itself.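

In this assay compound 3 gives > 60000 nM, a limit of the assay and not a number. Compound 1 also stands at a limit, so no step can be read between compound 1 and compound 3: the limit of > 60000 nM in this assay, at which 3 of the 3 values shown sit. The compounds shown leave open whether 4-methylphenyl and 4-fluorophenyl differ at all in binding.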